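From bromo to dimethylamino: estimating compound 4

A few compounds are considered here, and "the series" means these few. Any claim that something is new, unique, unknown or untested is made for them only; others in the source may bear on it.

Measured in a functional assay on SK-N-SH cells (Homo sapiens) for cytotoxicity, read by MTT assay, with a stated time of 24 h; on this read-out lower numbers stand for stronger inhibition and higher numbers for weaker inhibition:
compound 1 `COc1ccc(/C=C(\C#N)C(=O)N/N=C(\C)c2c(O)c3ccc(O)cc3oc2=O)cc1OC`: 21500 nM
compound 2 `COc1ccc(/C=C(\C#N)C(=O)N/N=C(\C)c2c(O)c3ccc(O)cc3oc2=O)cc1`: 9460 nM
compound 3 `C/C(=N\NC(=O)/C(C#N)=C/c1ccc(Br)cc1)c1c(O)c2ccc(O)cc2oc1=O`: 12100 nM

Compound 3 stands within the scatter of both other compounds, as a 1.3-fold higher number from compound 2 to compound 3 (0.11 log units; within the scatter) and a 1.8-fold lower number from compound 1 to compound 3 (0.25 log units; within the scatter) show. Compound 4 `C/C(=N\NC(=O)/C(C#N)=C/c1ccc(N(C)C)cc1)c1c(O)c2ccc(O)cc2oc1=O` has dimethylamino in place of bromo on an aromatic carbon, para to a large group: dimethylamino in place of bromo on an aromatic carbon. Going by the values given here, no measured compound carries dimethylamino, so the evidence is indirect. Among the compounds with values here, exchanging methoxy for bromo gave a 1.3-fold higher number from compound 2 to compound 3 (0.11 log units; within the scatter), and the only step beyond the scatter, a 2.3-fold lower number from compound 1 to compound 2 (0.36 log units; beyond the scatter), is modest. In this assay, the expected result is a 1.1-fold higher number from compound 3 to compound 4 (0.03 log units; within the scatter), with no shift beyond the scatter anticipated in either direction. For compound 4 the estimated value is 13000 nM, with an expected range of 6000 nM to 28000 nM.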

Compound 4, half-maximal inhibitory concentration: 6090 nM
Estimate against measurement, compound 4: 2.1-fold (0.33 log units) above; measured number inside the range.
By their numbers in this assay, from the lowest: compounds 4, 2, 3 and 1 (each within the scatter of the next, the first and the last beyond it).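

In this assay, dimethylamino on an aromatic carbon para to a large group stays within the scatter of both bromo (a 2.0-fold lower number from compound 3 to compound 4 (0.30 log units; within the scatter)) and methoxy (a 1.6-fold lower number from compound 2 to compound 4 (0.19 log units; within the scatter)). Only the wider exchange of 3,4-dimethoxyphenyl for 4-(dimethylamino)phenyl reaches beyond the scatter, and modestly so (a 3.5-fold lower number from compound 1 to compound 4 (0.55 log units; beyond the scatter)). Nothing available explains these numbers.

From the compounds shown here alone, whether a carboxylic acid or a longer chain at this place would move the number beyond the scatter of compound 4 remains open.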